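Cytotoxicity notes: phenyl in place of methyl on compound 1

This account rests on a few compounds, and the source may have more. Where it says the series, first, only, none or still open, it means among the compounds named here.

Measured in an ADME assay on MDBK cells (Bos taurus) for cytotoxicity; a higher number here means that more compound is tolerated, a lower number that less compound is tolerated:
- compound 1 `Cc1ccc(Cn2ccc3nc(-c4ccccc4)nc-3c2)cc1` gives > 100000 nM as a limit
- compound 2 `Fc1ccccc1Cn1ccc2nc(-c3ccccc3)nc-2c1` gives > 100000 nM as a limit

Compound 1 stands at > 100000 nM, which is a limit and not a number. Among the compounds with values here, the same holds for the only other measured compound, so the series offers the limit of > 100000 nM in this assay, at which 2 of the 2 values shown sit, and no measured number. Compound 3 `c1ccc(-c2ccc(Cn3ccc4nc(-c5ccccc5)nc-4c3)cc2)cc1` is the next compound to be tested. Its change from compound 1 is phenyl in place of methyl on an aromatic carbon, para to a large group. Within the data shown here, the only measured step is a step that the two limits leave unreadable from compound 1 to compound 2, which lies at a different place and gives no size to carry over. No step beyond the scatter is therefore expected in this assay, and this expectation rests only on compound 2, its step that the two limits leave unreadable from compound 1 to compound 2 and (the limit of > 100000 nM in this assay, at which 2 of the 2 values shown sit). The expected change is a number no higher from compound 1 to compound 3 (the limit leaves the size open), and a report of only a limit is the likeliest outcome. For compound 3 the estimated value is 100000 nM, with an expected range from 35000 nM to 200000 nM.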

Compound 3, half-maximal cytotoxic concentration: 18000 nM
The estimate for compound 3 lay 5.6-fold (0.74 log units) above the measured number; measured number below the stated range.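

In this assay, phenyl in place of methyl on an aromatic carbon, para to a large group, brings an at least 5.5-fold lower number from compound 1 to compound 3 (0.74 log units; beyond the scatter). Within the data shown here, this is the first readable step and shows that the group at this place can bring the number down into the measurable range, whereas the step from compound 1 to compound 2, at a different place, cannot be read. Among these compounds, compound 3 now holds the only measured number, and the size of its step stays open on the upper side, with the other values remaining at a limit: the limit of > 100000 nM in this assay, at which 2 of the 3 values shown sit.

The compounds shown do not tell whether the lower number follows the entering ring as such or simply the larger group, a question that an ethyl group, a longer chain or a cyclohexyl ring at the same place would address. They also leave open whether an amine or a carboxylic acid on the outer phenyl ring would keep the number of compound 3 or return it to the limit seen for compound 1.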